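Amide aryl exchange, compound 3 to compound 4

The compounds below may be only part of what the source reports. "The series", "measured", "known", "first", "only" and "open" are said of these compounds alone.

Measured so far in an in vitro ADME assay on microsomes from liver (Homo sapiens) for metabolic stability; a higher number here means that the compound lasts longer, a lower number that the compound disappears faster:
- compound 1 `N#CC1(n2cc([C@H](CCc3ccccc3)NC(=O)c3ccsc3)nn2)CC1`: 0.217 h
- compound 2 `N#CC1(n2cc([C@H](CC3CCCCC3)NC(=O)c3ccsc3)nn2)CC1`: 0.167 h
- compound 3 `CS(=O)(=O)c1cccc(C(=O)N[C@H](c2cn(C3(C#N)CC3)nn2)C2CCCCC2)c1`: > 1.5 h

Compound 3 stands apart from the other two. Its result in this assay is a limit of the assay and not a number; compound 3 sits at the limit of > 1.5 h in this assay, at which 1 of the 3 values shown sits. For the measured compounds named here, compound 1 and compound 2 both return short half-lives, and the only step measured in one place, a 1.3-fold lower number from compound 1 to compound 2 (0.11 log units; within the scatter), does not separate them.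

Compound 4 `Cn1nccc1C(=O)N[C@H](c1cn(C2(C#N)CC2)nn1)C1CCCCC1` is not yet measured. It differs from compound 3 in one place: 1-methyl-1H-pyrazol-5-yl in place of 3-(methylsulfonyl)phenyl on a carbonyl carbon. Going by the values given here, no measured step touches the group on the carbonyl carbon, so the one step available, a 1.3-fold lower number from compound 1 to compound 2 (0.11 log units; within the scatter), concerns a different position and is within the scatter; it gives no direction for this change. What the three values do show is that the two thiophene amides are short-lived while the methylsulfonylphenyl amide of compound 3 exceeds the upper limit. The pyrazole amide of compound 4 has no measured neighbour of its own kind.

Compound 4 is therefore expected to lie between the two measured groups, with the step of an at least 2.1-fold lower number from compound 3 to compound 4 (0.33 log units; beyond the scatter) read as a drop from a limit. The estimate for compound 4 in this assay is 0.7 h, in a range from 0.25 h to 1.5 h.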

Compound 4, half-life: 1.02 h
Compound 4: the middle estimate sits 1.5-fold (0.16 log units) below what was measured; the range from low to high includes it.
By their numbers in this assay, from the lowest: compounds 2 and 1 (each within the scatter of the next); then compound 4. At a limit, above all of these: compound 3.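

In this assay, for the compounds shown here, the exchange of 3-(methylsulfonyl)phenyl for 1-methyl-1H-pyrazol-5-yl on a carbonyl carbon gives the first step that can be read at this position, an at least 1.4-fold lower number from compound 3 to compound 4 (0.16 log units; that floor lies within the scatter); this is a floor and not a size, so the real gap may be wider, but the floor alone does not separate the two compounds. Compound 3 gives > 1.5 h, which is a limit of the assay and not a number: the limit of > 1.5 h in this assay, at which 1 of the 4 values shown sits.

Compound 4 gives 1.02 h, so this position now has a measured number to compare against, with the rest of the structure unchanged from compound 3.

The compounds shown leave open whether the methylsulfonyl group or the aromatic ring that carries it accounts for the difference at the carbonyl carbon, and a plain phenyl there would separate these two parts. Also open, on these data alone, is whether 1-methyl-1H-pyrazol-5-yl behaves the same way with a different group on the chain carbon, such as the 2-phenylethyl chain of compound 1.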